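The source may report more compounds than this note shows. Statements on the series, on what has been measured and on what is new or still open speak of the compounds shown alone.

Measured compounds:
compound 1, `COc1cccc(/C=C/C(=O)Nc2cc(OC)c(OC)c(OC)c2)c1`, 2400 nM
compound 2, `COc1ccc(C(=O)c2cc(OC)c(OC)c(OC)c2)cc1NC(=O)/C=C/c1cc(OC)c(OC)c(OC)c1`, 3100 nM

Of the compounds shown here, two have been tested in a functional assay on HT-29 cells (Homo sapiens) for cytotoxicity, read by MTT assay, with a stated time of 72 h; on this read-out higher numbers stand for weaker inhibition and lower numbers for stronger inhibition. Compound 1 gives 2400 nM, and compound 2 gives 3100 nM in this assay. Where compound 2 stands is easy to state: its number and that of compound 1 lie within the usual scatter of each other, so the two cannot be told apart on these data.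

Compound 3 is `COc1ccc(C(=O)c2cc(OC)c(OC)c(OC)c2)cc1NC(=O)/C=C/c1ccc(OC)c(OC)c1`, not yet measured. It differs from compound 2 in one place: hydrogen in place of methoxy on an aromatic carbon. In words, hydrogen in place of methoxy on an aromatic carbon, so that the ring on the cinnamoyl side goes from 3,4,5-trimethoxyphenyl to 3,4-dimethoxyphenyl.

Among the compounds with values here, no pair of measured compounds shows a step of this kind. Compound 1, which carries a single methoxy on that same ring, gives a number within the scatter of compound 2, which carries three. On that basis the step from compound 2 to compound 3 is expected to be small, with no clear direction beyond the scatter, as a 1.0-fold lower number from compound 2 to compound 3 (0.01 log units; within the scatter) expresses. Compound 3 is therefore expected to give about 3000 nM in this assay, with a range from 1200 nM to 8000 nM.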

Compound 3, half-maximal inhibitory concentration: 2500 nM
Compound 3: the middle estimate sits 1.2-fold (0.08 log units) above what was measured; the range from low to high includes it.
By their numbers in this assay, from the lowest: compounds 1, 3 and 2 (each within the scatter of the next).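

In this assay, within the data shown here, the change from 3,4,5-trimethoxyphenyl to 3,4-dimethoxyphenyl gives a 1.2-fold lower number from compound 2 to compound 3 (0.09 log units; within the scatter) and so offers the first direct look at this single position on the cinnamoyl side. The result shows that, in these cells and on this shared core, hydrogen in place of this methoxy brings no difference that can be told from ordinary repeat-to-repeat variation, whereas compound 1 and compound 2 differ in more than one place and could not isolate this position. Nothing available here offers an explanation for this outcome, so the result stands as an observation only.

The compounds shown compare only methoxy and hydrogen at this position, which leaves open how a hydroxyl, an amine, a fluorine or a longer chain such as ethoxy would read there. They also leave open whether the same replacement would read alike at the other methoxy groups on this ring, or whether removing two of them together would give a step beyond the scatter.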